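The source may report more compounds than this note shows. Statements on the series, on what has been measured and on what is new or still open speak of the compounds shown alone.

Working notes on the series, all read in a functional assay on A549 cells (Homo sapiens) for antiproliferative activity, read by MTT assay, with a stated time of 24 h; a lower number here means a stronger inhibitor of growth, a higher number a weaker inhibitor of growth. Compound 1 (`NC(=S)N1N=C(c2ccc(Cl)c(Cl)c2)CC1c1ccc(O)cc1`) gives 33500 nM and compound 2 (`NC(=S)N1N=C(c2ccc(Br)cc2)CC1c1ccc2ccccc2c1`) gives 230 nM. Compound 2 therefore holds the lower of the two numbers, and the gap between them lies beyond the scatter. Compound 3 (`NC(=S)N1N=C(c2ccccc2)CC1c1ccc2ccccc2c1`) is compound 2 with hydrogen in place of bromo on an aromatic carbon, para to a large group, the change from 4-bromophenyl to phenyl: hydrogen in place of bromo on an aromatic carbon. Going by the values given here, no measured pair shows this change on its own, so the expectation rests on little. A moderate rise in the number in this assay is expected, meaning weaker inhibition of growth, though a step within the scatter remains possible. The estimated step is a 3.0-fold higher number from compound 2 to compound 3 (0.48 log units; beyond the scatter). For compound 3 the expected value is 700 nM, with an estimated range of 170 nM to 4000 nM.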

Compound 3, concentration for 50% growth inhibition: 3210 nM
Beside the measured number, compound 3's estimate is 4.6-fold (0.66 log units) below it; the measured number falls inside the stated range.
By their numbers in this assay, from the lowest: compound 2; then compound 3; then compound 1.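

The 4-bromophenyl group now has its first single-place comparison: in this assay, hydrogen in place of bromo on an aromatic carbon gives a 14-fold higher number from compound 2 to compound 3 (1.14 log units; beyond the scatter) as a large step. This shows that the substituent at this carbon, para to a large group, matters to the number in this series, which the unmatched compound 1 and compound 2 could not show. No measurement in hand bears on why the step is this large.

Only bromo and hydrogen are compared at this carbon, so fluoro, methoxy or an amine could fall anywhere relative to compound 2 and compound 3. Compound 1 differs from both in more than one place, so its steps to them cannot be read.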